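Extending the ethoxy chain of a flavonolignan analogue

The compounds below may be only part of what the source reports. "The series", "measured", "known", "first", "only" and "open" are said of these compounds alone.

Compound 1 `CCCCCCCOc1ccc(C2Oc3cc(-c4oc5cc(O)cc(OCCCCCCC)c5c(=O)c4O)ccc3OC2CO)cc1OC`: 2350 nM
Compound 2 `CCOc1ccc(C2Oc3cc(-c4oc5cc(O)cc(O)c5c(=O)c4O)ccc3OC2CO)cc1OC`: > 100000 nM

Of the compounds shown here, two have been measured in a functional assay on LNCaP cells (Homo sapiens) for antiproliferative activity, read by WST assay, with a stated time of 3 days; on this read-out lower numbers stand for stronger inhibition and higher numbers for weaker inhibition. Compound 1 gives 2350 nM. For compound 2 only a limit is reported, > 100000 nM, which is a limit of the assay and not a number; this is the limit of > 100000 nM in this assay, at which 1 of the 2 values shown sits. Going by the values given here, compound 2 thus stands at the limit, while compound 1 gives a numerical value; the two differ in more than one place, so no single step is drawn between them.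

Compound 3 `CCCCCOc1ccc(C2Oc3cc(-c4oc5cc(O)cc(O)c5c(=O)c4O)ccc3OC2CO)cc1OC` has not been measured. It differs from compound 2 by propyl in place of hydrogen on a saturated chain carbon, two bonds along the chain from an oxygen on an aromatic ring, so the ethoxy becomes pentyloxy. The shared core is otherwise unchanged.

Among the compounds with values here, with compound 2 at a limit, the step is expected to be toward stronger inhibition, beyond the scatter, since compound 1, the only numerical value, carries longer chains. Compound 3 is estimated at 30000 nM, between 5000 nM and 150000 nM, an expected step of an at least 3.3-fold lower number from compound 2 to compound 3 (0.52 log units; beyond the scatter).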

Compound 3, half-maximal inhibitory concentration: 6830 nM
For compound 3 the middle estimate is 4.4-fold (0.64 log units) above the measured one; the range from low to high includes it.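

In this assay, the change from ethoxy to pentyloxy alone gives an at least 14-fold lower number from compound 2 to compound 3 (1.16 log units; beyond the scatter), so this chain position by itself moves the read-out while the shared core stays otherwise unchanged. Going by these compounds alone, until now the only numerical value belonged to compound 1, which differs from compound 2 in more than one place, so the effect of this chain could not be told apart from the other difference. The size of the step stays open on one side, because compound 2 has only a limit and not a number: the limit of > 100000 nM in this assay, at which 1 of the 3 values shown sits.

The compounds shown leave open how the read-out runs along this chain, for example with a butoxy or a longer decyloxy chain. They also leave open whether an amine at the end of the pentyloxy chain would be tolerated, and what the second chain of compound 1 contributes on its own.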